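This account rests on a few compounds, and the source may have more. Where it says the series, first, only, none or still open, it means among the compounds named here.

Working notes on the series. The shared core of compound 1 `Cc1cc(O)c(C(=O)/C=C/c2ccc(Cl)cc2)c(-c2ccc(Cl)cc2)c1C(=O)/C=C/c1ccc(Cl)cc1` carries two enone arms and a pendant aryl ring; in a functional assay on HeLa cells (Homo sapiens) for cytotoxicity, read by MTT assay, with a stated time of 24 h (a higher number here means a weaker inhibitor, a lower number a stronger inhibitor), compound 1 is recorded as "not active" (no number reported), with no number behind that word. Compound 2 `Cc1cc(O)c(C(=O)/C=C/c2cccc3ccccc23)c(-c2ccccc2)c1C(=O)/C=C/c1cccc2ccccc12` stands the same way: in this assay compound 2 is given as "not active" (no number reported), again without a number. Among the compounds with values here, compound 3 `Cc1cc(O)c(C(=O)/C=C/c2ccc(OCc3ccccc3)cc2)c(-c2ccccc2)c1C(=O)/C=C/c1ccc(OCc2ccccc2)cc1` is the only member of the set with a figure, and in this assay compound 3 gives 20000 nM. So compound 1 stands among the entries that carry no single number, and the one numbered neighbour sits at a weak level; no step between any two measured compounds can be computed.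

Compound 4 `Cc1cc(O)c(C(=O)/C=C/c2ccc(Cl)cc2)c(-c2ccc(Br)cc2)c1C(=O)/C=C/c1ccc(Cl)cc1` is the untested member. It differs from compound 1 by one substitution, (bromo in place of chloro on an aromatic carbon), that is, a bromo in place of a chloro on an aromatic carbon, para to a large group. Within the data shown here, no step of this kind is known within the set, so no direction can be read from the data; the expectation is a step of no more than the usual scatter, in either direction, from wherever compound 1 truly lies.

Given that compound 1 carries no number, compound 4 is expected to read about 40000 nM in this assay, estimated between 15000 nM and 120000 nM, with a real chance that only a non-active call and no number is returned.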

Compound 4, half-maximal inhibitory concentration: 32000 nM
For compound 4 the middle estimate is 1.3-fold (0.10 log units) above the measured one; the measured number falls inside the stated range.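

In this assay compound 4 gives 32000 nM, while compound 1 is recorded as "not active" (no number reported), so no step can be read between compound 1 and compound 4. The compounds shown leave open how far the change from 4-chlorophenyl to 4-bromophenyl moves the read-out. No data at hand bear on this result.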